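A few compounds are considered here, and "the series" means these few. Any claim that something is new, unique, unknown or untested is made for them only; others in the source may bear on it.

Compound 3, whose structure is `CC(CC[C@H]1/C(=C/c2ccc(Cl)cc2)CC[C@H]2C(C)(C)CCC[C@]12C)CC(=O)O`, belongs to a small series of three measured acids that share one core and differ only in the group on the aromatic ring. In a functional assay on THP-1 cells (Homo sapiens) for cytotoxicity, read by MTT assay, with a stated time of 72 h (a lower number here means a stronger inhibitor, a higher number a weaker inhibitor), compound 3 gives > 200000 nM, which is a limit of the assay and not a number. Within the data shown here, compound 1, with structure `Cc1ccc(/C=C2\CC[C@H]3C(C)(C)CCC[C@]3(C)[C@H]2CCC(C)CC(=O)O)cc1`, is the one member with a numerical value: in this assay compound 1 gives 91000 nM. Compound 2, with structure `CC(CC[C@H]1/C(=C/c2ccc(F)cc2)CC[C@H]2C(C)(C)CCC[C@]12C)CC(=O)O`, again returns a limit of the assay in this assay, namely > 200000 nM. The two readable steps both run from compound 1 upward: an at least 2.1-fold higher number from compound 1 to compound 2 (0.34 log units; beyond the scatter) and an at least 2.1-fold higher number from compound 1 to compound 3 (0.34 log units; beyond the scatter). The step that the two limits leave unreadable from compound 2 to compound 3 cannot be sized, since (the limit of > 200000 nM in this assay, at which 2 of the 3 values shown sit).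

Compound 4, with structure `CC(CC[C@H]1/C(=C/c2ccc(Br)cc2)CC[C@H]2C(C)(C)CCC[C@]12C)CC(=O)O`, is obtained from compound 3 by bromo in place of chloro on an aromatic carbon. Among the measured compounds shown here, only the step from compound 2 to compound 3 bears on a halogen exchange, and its size is unreadable. The writer therefore expects for compound 4 a step in this assay of a step that the limit leaves unreadable from compound 3 to compound 4, that is, none beyond the scatter, most probably another limit. The expected value for compound 4 is 250000 nM, between 100000 nM and 700000 nM.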

Compound 4, half-maximal inhibitory concentration: > 200000 nM
Compound 4: no number, only a limit; the forecaster's own chance of this, stated with the estimate: 75%; the middle value lies beyond the limit too.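

With bromo on the aromatic carbon para to a large group, a third halogen now reads as weaker than the methyl-bearing member in this assay, with an at least 2.1-fold higher number from compound 1 to compound 4 (0.34 log units; beyond the scatter). This extends to the heaviest halogen shown what fluoro and chloro had already shown, so the result for compound 1 stands alone in this series of four. The steps among compound 2, compound 3 and compound 4 cannot be read, so the change from 4-chlorophenyl to 4-bromophenyl has no size and the halogens have no order: the limit of > 200000 nM in this assay, at which 3 of the 4 values shown sit.

As far as these compounds go, whether the halogens differ at all beyond that limit stays open. Also open, from the compounds shown here alone, is what an amine, a hydroxyl or an ethyl group at this place on the ring would give in this assay, and whether any of them would give a lower number than the methyl group.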